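A few compounds are considered here, and "the series" means these few. Any claim that something is new, unique, unknown or untested is made for them only; others in the source may bear on it.

In an ADME assay on MDBK cells (Bos taurus) for cytotoxicity, read by MTT assay, with a stated time of 96 h (a higher number here means that more compound is tolerated, a lower number that less compound is tolerated), compound 1 (`CC(=O)c1ccc2[nH]c(-c3ccccc3)nc2c1`) gives > 100000 nM as a limit. Compound 2 (`CC(=O)c1ccc2[nH]c(-c3ccc(C(F)(F)F)cc3)nc2c1`) gives > 100000 nM as a limit too. Compound 3 (`C/C(=N\O)c1ccc2[nH]c(-c3ccccc3)nc2c1`) gives > 100000 nM as a limit also. Compound 1 thus stands at the limit of > 100000 nM in this assay, at which 3 of the 3 values shown sit, and has no number. Compound 4 (`CC(=O)c1ccc2c(c1)nc(-c1ccccc1)n2C1CCCCC1`) has cyclohexyl in place of hydrogen on an aromatic nitrogen next to the ring atom that bears a phenyl group. Only a step that the two limits leave unreadable from compound 1 to compound 2 and a step that the two limits leave unreadable from compound 1 to compound 3 bear on it, and neither gives a size to carry over. A moderate step toward less compound tolerated is expected, an at least 1.6-fold lower number from compound 1 to compound 4 (0.22 log units; that floor lies within the scatter) in this assay as a loose guess. For compound 4 the estimated value is 60000 nM with an expected range from 20000 nM to 100000 nM at the upper end, and a limit remains quite possible.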

Compound 4, half-maximal cytotoxic concentration: > 100000 nM
Compound 4 gave a limit, no number; the forecaster's own chance of this, stated with the estimate: 50%; middle value at least 1.6-fold (0.22 log units) from the limit.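

Compound 4, like compound 1, gives only a limit in this assay, so no step can be read between them: the limit of > 100000 nM in this assay, at which 4 of the 4 values shown sit.

The compounds shown leave open whether any change to the shared core alters tolerance, since none yet has a number.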